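The source may report more compounds than this note shows. Statements on the series, on what has been measured and on what is new or still open speak of the compounds shown alone.

Compound 1 `COc1ccccc1-c1cc(=O)c2cc(N)ccc2o1` is one of three aminochromone-bearing compounds measured in an ADME assay on THP-1 cells (Homo sapiens) for cytotoxicity, read by flow cytometry and propidium iodide staining, with a stated time of 72 h (a lower number here means a stronger inhibitor, a higher number a weaker inhibitor), and within this set compound 1 gives 74000 nM, the highest of the three numbers. Compound 2 `Nc1ccc2oc(-c3ccccc3F)cc(=O)c2c1` gives 44000 nM in this assay, and compound 3 `Nc1ccc2oc(-c3ccc(F)cc3)cc(=O)c2c1` gives 10000 nM. Within the data shown here, the only step between neighbouring measured compounds is a 1.7-fold lower number from compound 1 to compound 2 (0.23 log units; within the scatter), which concerns a fluoro in place of methoxy and falls within the scatter; the gap from compound 1 to compound 3 is wider, as their two values show, but those two structures differ in more than one place.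

Compound 4 `COc1ccccc1-c1oc2ccc(N)cc2c(=O)c1O` is not yet measured. It differs from compound 1 by hydroxy in place of hydrogen on an aromatic carbon. Among the measured compounds shown here, no measured step involves a hydroxy entering or leaving, so nothing in the measured set speaks for or against a shift in this assay from this change. Because the neighbouring step a 1.7-fold lower number from compound 1 to compound 2 (0.23 log units; within the scatter) stayed within the scatter, the expectation for compound 4 is a step of a 1.2-fold lower number from compound 1 to compound 4 (0.09 log units; within the scatter), no larger than the scatter. Compound 4 is therefore estimated at 60000 nM, within a range of 20000 nM to 180000 nM.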

Compound 4, half-maximal inhibitory concentration: 102000 nM
Compound 4: the middle estimate sits 1.7-fold (0.23 log units) below what was measured, and the stated range covers the measured number.
By their numbers in this assay, from the lowest: compound 3; then compounds 2, 1 and 4 (each within the scatter of the next, the first and the last beyond it).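

In this assay, placing hydroxy on an aromatic carbon of the six-membered aromatic ring with 1 oxygen, two atoms from the ring oxygen, gives a 1.4-fold higher number from compound 1 to compound 4 (0.14 log units; within the scatter) and so leaves compound 4 indistinguishable from compound 1. Among these compounds, the earlier compounds varied only the substituent on the other aromatic ring and all carried hydrogen at this carbon, so this is the first reading of a change at this position, and a single hydroxy there produces no shift that can be separated from the scatter. No other data on these compounds bear on this result.

From the compounds shown here alone, whether a larger or differently charged group at this carbon, such as a methyl group, a chlorine atom or a carboxylic acid, would also leave the number unmoved remains open. So does whether the same hydroxy would have as little effect on compound 3, which carries a fluoro in a different place on the other ring.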